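This account rests on a few compounds, and the source may have more. Where it says the series, first, only, none or still open, it means among the compounds named here.

In a functional assay on MES-SA cells (Homo sapiens) for cytotoxicity, read by luminescence and CellTiter-Glo, with a stated time of 72 h (on this read-out lower numbers stand for stronger inhibition and higher numbers for weaker inhibition), compound 1 `COC[C@H](NC(=O)c1cc(C)on1)C(=O)N[C@@H](CC1CCCCC1)C(=O)N[C@@H](CC(C)C)C(=O)[C@@]1(C)CO1` gives 353 nM and compound 2 `COC[C@H](NC(=O)c1cc(C)on1)C(=O)N[C@@H](CC(C)C)C(=O)N[C@@H](CC(C)C)C(=O)[C@@]1(C)CO1` gives 366 nM, two values within the scatter of each other. Compound 3 `COC[C@H](NC(=O)c1cc(C)on1)C(=O)N[C@@H](COC)C(=O)N[C@@H](CC(C)C)C(=O)[C@@]1(C)CO1` gives 145 nM, the lowest number of the set and the most potent of these compounds.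

Compound 4 `COC[C@H](NC(=O)c1cc(C)on1)C(=O)N[C@H](C(=O)N[C@@H](CC(C)C)C(=O)[C@@]1(C)CO1)C(C)C` changes compound 3 in one place: isopropyl in place of methoxymethyl on a saturated chain carbon bound to an amide-type nitrogen and a carbonyl carbon. Here, isopropyl stands in place of methoxymethyl on a saturated chain carbon bound to an amide-type nitrogen and a carbonyl carbon.

Among the compounds with values here, no measured pair makes exactly this change, but three steps in the same part of the molecule bear on it. Exchanging one carbon group for another made no clear difference, with a 1.0-fold higher number from compound 1 to compound 2 (0.02 log units; within the scatter). Bringing in methoxy mattered more, with a 2.4-fold lower number from compound 1 to compound 3 (0.39 log units; beyond the scatter) and a 2.5-fold lower number from compound 2 to compound 3 (0.40 log units; beyond the scatter), both modest. Compound 4 removes the methoxy unit, so a modest rise of similar size is expected in this assay. The comparison is loose, since those exchanges lay two bonds along the chain and this one lies on the chain carbon itself.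

The expected change is a 2.1-fold higher number from compound 3 to compound 4 (0.32 log units; beyond the scatter). For compound 4 the estimated value is 300 nM, with an expected range from 120 nM to 750 nM.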

Compound 4, half-maximal inhibitory concentration: 636 nM
For compound 4 the middle estimate is 2.1-fold (0.33 log units) below the measured one; low and high end bracket the measured number.
By their numbers in this assay, from the lowest: compound 3; then compounds 1, 2 and 4 (each within the scatter of the next).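

At this saturated chain carbon bound to an amide-type nitrogen and a carbonyl carbon, replacing methoxymethyl with isopropyl, an exchange that swaps one oxygen for one carbon in a group of the same heavy-atom count, gives a 4.4-fold higher number from compound 3 to compound 4 (0.64 log units; beyond the scatter) in this assay. Among the all-carbon groups, isopropyl cannot be told apart from isobutyl, with a 1.7-fold higher number from compound 2 to compound 4 (0.24 log units; within the scatter), or from cyclohexylmethyl, with a 1.8-fold higher number from compound 1 to compound 4 (0.26 log units; within the scatter), so a small branched group and a much larger ring-bearing group read alike, and of the four groups only methoxymethyl stands apart, with compound 3 lowest. Nothing measured here explains why the oxygen-bearing group differs from the others.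

The compounds shown leave open whether the ether oxygen is what counts or whether any group other than an all-carbon one would serve, which a hydroxymethyl, ethoxymethyl or aminomethyl group at this carbon could begin to show. They also leave open how a carboxylic acid or a longer ether chain, such as methoxyethyl, would read in this assay.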